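Aryl exchange on the saturated ring carbon: compound 4

This account rests on a few compounds, and the source may have more. Where it says the series, first, only, none or still open, it means among the compounds named here.

The series shares one core. Compound 1 `CC1=C(C(=O)Nc2ccc(Cl)cc2)C(c2ccco2)C(C(=O)Nc2ccc(Cl)cc2)=C(C)N1` carries furan-2-yl on a saturated ring carbon, compound 2 `COc1cc(C2C(C(=O)Nc3ccc(Cl)cc3)=C(C)NC(C)=C2C(=O)Nc2ccc(Cl)cc2)ccc1O` carries 4-hydroxy-3-methoxyphenyl there, and compound 3 `CC1=C(C(=O)Nc2ccc(Cl)cc2)C(c2cccc([N+](=O)[O-])c2)C(C(=O)Nc2ccc(Cl)cc2)=C(C)N1` carries 3-nitrophenyl. In an ADME assay on Vero cells (Chlorocebus sabaeus) for cytotoxicity, read by sulforhodamine B assay, with a stated time of 3 days (a higher number here means that more compound is tolerated, a lower number that less compound is tolerated), compound 1 gives 24 ug/mL, compound 2 gives 250 ug/mL and compound 3 gives 26 ug/mL. Compound 3 thus stands second highest of the three numbers, with compound 1 nearest and compound 2 furthest: a 1.1-fold higher number from compound 1 to compound 3 (0.03 log units; within the scatter) and a 9.6-fold lower number from compound 2 to compound 3 (0.98 log units; beyond the scatter).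

Compound 4 `CC1=C(C(=O)Nc2ccc(Cl)cc2)C(C/C=C/c2ccccc2)C(C(=O)Nc2ccc(Cl)cc2)=C(C)N1` is the next change at the same place: 3-phenylprop-2-en-1-yl in place of 3-nitrophenyl on a saturated ring carbon. Going by the values given here, two measured steps bear on this position. a 1.1-fold higher number from compound 1 to compound 3 (0.03 log units; within the scatter) shows that one aromatic group can replace another here without moving this assay, whereas a 10-fold higher number from compound 1 to compound 2 (1.02 log units; beyond the scatter) and a 9.6-fold lower number from compound 2 to compound 3 (0.98 log units; beyond the scatter) show that only the group with the hydroxy raised the number. The group entering in compound 4 has 0 hydrogen-bond donors and 0 hydrogen-bond acceptors, which puts it with compound 1 and compound 3 rather than with compound 2. Because a 1.1-fold higher number from compound 1 to compound 3 (0.03 log units; within the scatter) lay within the scatter, compound 4 is expected to show a 1.2-fold higher number from compound 3 to compound 4 (0.06 log units; within the scatter), nothing beyond the scatter. The estimate for compound 4 in this assay is 30 ug/mL, in the range 10 ug/mL to 90 ug/mL.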

Compound 4, half-maximal cytotoxic concentration: 21 ug/mL
Compound 4: the middle estimate sits 1.4-fold (0.15 log units) above what was measured; the measured number falls inside the stated range.
By their numbers in this assay, from the lowest: compounds 4, 1 and 3 (each within the scatter of the next); then compound 2.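

In this assay, replacing 3-nitrophenyl with 3-phenylprop-2-en-1-yl gives a 1.2-fold lower number from compound 3 to compound 4 (0.09 log units; within the scatter), so this position tolerates the loss of the nitrogen, the oxygens and the hydrogen-bond acceptors of the leaving group with no change beyond the scatter. The entering group reaches the saturated ring carbon through a chain rather than through an aromatic ring, and this also leaves the number within the scatter of the furan-2-yl compound, with a 1.1-fold lower number from compound 1 to compound 4 (0.06 log units; within the scatter). The new chain also gives a 12-fold lower number from compound 2 to compound 4 (1.08 log units; beyond the scatter), so among the four groups shown 4-hydroxy-3-methoxyphenyl alone stands apart, while compound 1, compound 3 and compound 4 lie within the scatter of one another and no compound goes against this.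

The series does not separate the hydroxy from the methoxy of compound 2, and a lone hydroxy or methoxy on the phenyl ring, an amine or a carboxylic acid at this position would test whether a hydrogen-bond donor of any kind goes with the higher number. No measurement at hand explains why compound 2 stands apart in this assay or why the other three groups do not differ.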